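Swapping the dimethylamino end of compound 1 for 3-aminopropyl

This account rests on a few compounds, and the source may have more. Where it says the series, first, only, none or still open, it means among the compounds named here.

In a functional assay on HT-29 cells (Homo sapiens) for cytotoxicity, read by MTT assay, with a stated time of 72 h (on this read-out lower numbers stand for stronger inhibition and higher numbers for weaker inhibition), compound 1 `CN(C)CCCNc1c(C(=O)NCc2ccc(F)cc2)nc(Br)c2cccnc12` gives 6000 nM. Compound 2 `O=C(NCc1ccc(F)cc1)c1nc(Br)c2cccnc2c1N1CCNCC1` gives 10000 nM, which lies within the scatter of the value for compound 1, so the two cannot be ordered. Compound 3 `NCCCNc1c(C(=O)NCc2ccc(F)cc2)ncc2cccnc12` gives > 10000 nM, and this value is a limit, not a number.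

Compound 4 `NCCCCCCNc1c(C(=O)NCc2ccc(F)cc2)nc(Br)c2cccnc12` has not yet been measured. It differs from compound 1 by 3-aminopropyl in place of dimethylamino on a saturated chain carbon, three bonds along the chain from a nitrogen on an aromatic ring. Cut further out, the same difference reads 3-(dimethylamino)propyl to 6-aminohexyl.

Going by the values given here, no measured step makes this exact change. The only one that bears on it replaces the whole side chain with piperazin-1-yl. Because a 1.7-fold higher number from compound 1 to compound 2 (0.22 log units; within the scatter) stayed within the scatter, no step beyond the scatter is expected in this assay, and no direction can be favoured with confidence. The expected step is a 1.2-fold lower number from compound 1 to compound 4 (0.08 log units; within the scatter). Compound 4 is estimated at 5000 nM, with an expected range of 1800 nM to 15000 nM.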

Compound 4, half-maximal inhibitory concentration: 5000 nM
Compound 4: middle estimate and measured number agree at the digits printed; measured number inside the range.
By their numbers in this assay, from the lowest: compounds 4, 1 and 2 (each within the scatter of the next).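

Replacing the dimethylamino end with 3-aminopropyl, which turns the 3-(dimethylamino)propyl chain into 6-aminohexyl, gives a 1.2-fold lower number from compound 1 to compound 4 (0.08 log units; within the scatter), so in this assay this change at the saturated chain carbon leaves no readable difference. Set against piperazin-1-yl on the aromatic carbon, the (6-aminohexyl)amino chain gives a 2.0-fold lower number from compound 2 to compound 4 (0.30 log units; within the scatter), so none of the three side chains with a number can be ordered against another. Compound 3 has a limit and not a number, and so stands outside this comparison: the limit of > 10000 nM in this assay, at which 1 of the 4 values shown sits.

From the compounds shown here alone, whether a carboxylic acid, a hydroxyl group or a still longer chain at the end of this side chain would shift the number beyond the scatter remains open. Also open, going by these compounds, is what a chlorine atom or a methyl group in place of the bromine would do with the 6-aminohexyl chain kept.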